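One Methoxy Less: From Compound 2 to Compound 3

A few compounds are considered here, and "the series" means these few. Any claim that something is new, unique, unknown or untested is made for them only; others in the source may bear on it.

compound 1 `CCCCCC1=CC(=N)C(C)(C)O1` — 98.3 ug/mL
compound 2 `COc1ccccc1C1=CC(=O)CO1` — > 100 ug/mL

Of the compounds shown here, two have been tested in a functional assay on L1210 cells (Mus musculus); a lower number here means a stronger inhibitor, a higher number a weaker inhibitor. Compound 1 `CCCCCC1=CC(=N)C(C)(C)O1` gives 98.3 ug/mL. For compound 2 `COc1ccccc1C1=CC(=O)CO1` the assay reports only a limit, > 100 ug/mL, so compound 2 sits at the limit of > 100 ug/mL in this assay, at which 1 of the 2 values shown sits. Compound 3 `O=C1C=C(c2ccccc2)OC1` differs from compound 2 by hydrogen in place of methoxy on an aromatic carbon. Among the measured compounds shown here, no step between measured compounds is available, so in this assay the change is expected to be small, within the usual scatter, in either direction. Compound 3 is estimated at 150 ug/mL, between 60 ug/mL and 400 ug/mL, an expected step that the limit leaves unreadable from compound 2 to compound 3, and the assay may again report only a limit.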

Compound 3, concentration for 50% inhibition: 45.8 ug/mL
For compound 3 the middle estimate is 3.3-fold (0.52 log units) above the measured one; measured number below the stated range.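

In this assay, hydrogen in place of methoxy gives an at least 2.1-fold lower number from compound 2 to compound 3 (0.33 log units; beyond the scatter), so this aromatic carbon is a place where a change can move the number beyond the usual scatter. Compound 2 has only a limit, > 100 ug/mL. The step is therefore read from a limit and not from two exact numbers: the limit of > 100 ug/mL in this assay, at which 1 of the 3 values shown sits.

Only methoxy and hydrogen are compared at this place. On these data alone, how a fluorine, a hydroxyl or an amine on the same carbon would read remains open, as does the full size of this step.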